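The source may report more compounds than this note shows. Statements on the series, on what has been measured and on what is new or still open speak of the compounds shown alone.

Measured so far:
compound 1 `NC(=O)c1c(NC(=O)c2ccccc2Cl)sc2c1CCN(Cc1ccc([N+](=O)[O-])cc1)C2` — 46100 nM
compound 2 `NC(=O)c1c(NC(=O)c2ccccc2F)sc2c1CCN(Cc1c(Cl)cccc1Cl)C2` — 33000 nM

Both numbers come from a functional assay on HeLa cells (Homo sapiens) for antiproliferative activity, with a stated time of 24 h; on this read-out lower numbers stand for stronger inhibition and higher numbers for weaker inhibition. In this assay compound 1 stands highest of the two numbers, with compound 2 nearest; that gap lies within the scatter, so the two values show no difference between them.

Compound 3 `NC(=O)c1c(NC(=O)c2ccccc2Cl)sc2c1CCN(C(=O)Nc1c(Cl)cccc1Cl)C2` differs from compound 1 in one place: (2,6-dichlorophenyl)carbamoyl in place of 4-nitrobenzyl on an amine nitrogen in a ring. For the measured compounds named here, no measured pair covers this change, so nothing sets its size. The step is expected to stay within the scatter, in no clear direction, a 1.2-fold lower number from compound 1 to compound 3 (0.08 log units; within the scatter). For compound 3 the estimate in this assay is 38000 nM, with a range of 10000 nM to 120000 nM.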

Compound 3, half-maximal inhibitory concentration: 27200 nM
Compound 3: the middle estimate sits 1.4-fold (0.15 log units) above what was measured; measured number inside the range.
By their numbers in this assay, from the lowest: compounds 3, 2 and 1 (each within the scatter of the next).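

In this assay the exchange of 4-nitrobenzyl for (2,6-dichlorophenyl)carbamoyl on the amine nitrogen in a ring gives a 1.7-fold lower number from compound 1 to compound 3 (0.23 log units; within the scatter), so even this change of linking group leaves the number within the scatter. The nitrogen therefore carries either group with no readable difference in this read-out. No measurement on this step offers an explanation for it. Still open, on these data alone, is whether a methyl group, an acetyl group or a group bearing a carboxylic acid on this nitrogen would move the number beyond the scatter.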